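A few compounds are considered here, and "the series" means these few. Any claim that something is new, unique, unknown or untested is made for them only; others in the source may bear on it.

In a functional assay on NCI-H146 cells (Homo sapiens) for inhibition, read by WST assay, with a stated time of 4 days (a higher number here means a weaker inhibitor, a lower number a stronger inhibitor), compound 1 `CNC(=O)c1c(-c2cccc(N3CCN(c4ccc(NS(=O)(=O)c5ccc(N[C@H](CCN(C)C)CSc6ccccc6)c([N+](=O)[O-])c5)cc4)CC3)c2)c(-c2ccc(Cl)cc2)n(C)c1C` gives 36 nM and compound 2 `Cc1c(C(=O)N[C@H]2C[C@@](C)(O)C2)c(-c2cccc(N3CCN(c4ccc(NS(=O)(=O)c5ccc(N[C@H](CCN(C)C)CSc6ccccc6)c([N+](=O)[O-])c5)cc4)CC3)c2)c(-c2ccc(Cl)cc2)n1C` gives 12 nM, with a 3.0-fold lower number from compound 1 to compound 2 (0.48 log units; beyond the scatter). Compound 3 `Cc1c(C(F)(F)F)c(-c2cccc(N3CCN(c4ccc(NS(=O)(=O)c5ccc(N[C@H](CCN(C)C)CSc6ccccc6)c([N+](=O)[O-])c5)cc4)CC3)c2)c(-c2ccc(Cl)cc2)n1C` gives > 1000 nM, which is a limit of the assay and not a number. It therefore has no exact place in the series, only a position on the weak side of the two amides.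

Compound 4 `Cc1c(C#N)c(-c2cccc(N3CCN(c4ccc(NS(=O)(=O)c5ccc(N[C@H](CCN(C)C)CSc6ccccc6)c([N+](=O)[O-])c5)cc4)CC3)c2)c(-c2ccc(Cl)cc2)n1C` puts cyano in place of trifluoromethyl on an aromatic carbon. Going by the values given here, no measured step makes this exchange directly. The nearest evidence is at the same carbon, where trifluoromethyl replaces the amide groups, with an at least 27-fold higher number from compound 1 to compound 3 (1.44 log units; beyond the scatter) and an at least 83-fold higher number from compound 2 to compound 3 (1.92 log units; beyond the scatter), both large. These steps show that this carbon can shift the number strongly, but they do not place cyano on that scale. A partial return towards the amides is expected, since compound 1 at 36 nM remains the nearest numeric reference. A result at the limit remains possible.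

The expected change is an at least 3.3-fold lower number from compound 3 to compound 4 (0.52 log units; beyond the scatter), towards a lower number. For compound 4 the estimate is 300 nM, with an expected range of 60 nM to 1000 nM.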

Compound 4, half-maximal inhibitory concentration: 491 nM
Compound 4: the middle estimate sits 1.6-fold (0.21 log units) below what was measured; the measured number falls inside the stated range.
By their numbers in this assay, from the lowest: compound 2; then compound 1; then compound 4. At a limit, above all of these: compound 3.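

In this assay compound 4 gives 491 nM, so cyano is the one group without an amide shown at this aromatic carbon that returns a number. The exchange of trifluoromethyl for cyano gives an at least 2.0-fold lower number from compound 3 to compound 4 (0.30 log units; that floor lies within the scatter), a step that rests on the limit of compound 3, so no order between the two is claimed: the limit of > 1000 nM in this assay, at which 1 of the 4 values shown sits. Cyano does not match either amide, with a 14-fold higher number from compound 1 to compound 4 (1.13 log units; beyond the scatter) and a 41-fold higher number from compound 2 to compound 4 (1.61 log units; beyond the scatter), so both amides stay well ahead of it at this carbon.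

From the compounds shown here alone, whether a carboxylic acid, an aminomethyl group or a longer amide chain on this carbon would track the amides or cyano remains open. The compounds shown also do not separate the carbonyl from the amide hydrogen as the part that matters.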